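This account rests on a few compounds, and the source may have more. Where it says the series, first, only, none or still open, it means among the compounds named here.

Compound 1 `COc1ccccc1C(=O)NCc1ccc(CNS(=O)(=O)c2ccccc2)cc1` carries an amide on one side of a shared core and a sulfonamide on the other. In an assay on MDA-MB-231 cells for binding affinity to C-X-C chemokine receptor type 4 (Homo sapiens), read by immunofluorescence and microscopy, with stated times of 10 min and 30 min (on this read-out higher numbers stand for an effect only at larger amounts of compound and lower numbers for an effect already at smaller amounts), compound 1 gives 1 nM, the lowest of the three numbers measured, so it is the most potent of the three. Compound 3 `COc1ccccc1C(=O)NCc1ccc(CNS(=O)(=O)c2ccc(C)cc2)cc1` gives 100 nM in this assay, and compound 2 `Cc1ccc(S(=O)(=O)NCc2ccc(CNC(=O)c3cccc(C)c3)cc2)cc1` gives 1000 nM. A small change on the sulfonamide side, methyl in place of hydrogen on an aromatic carbon, gives a 100-fold higher number from compound 1 to compound 3 (2.00 log units; beyond the scatter). On the amide side, 2-methoxyphenyl in place of 3-methylphenyl on a carbonyl carbon gives a 10-fold lower number from compound 2 to compound 3 (1.00 log units; beyond the scatter), so the group on the carbonyl carbon also moves the number.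

Compound 4 `O=C(NCc1ccc(CNS(=O)(=O)c2ccccc2)cc1)c1c(Cl)cc(Cl)cc1Cl` differs from compound 1 in exactly that place: 2,4,6-trichlorophenyl in place of 2-methoxyphenyl on a carbonyl carbon. The entering group has not been measured in this series, but both measured steps show that the numbers react strongly to changes of the aryl groups, and 2-methoxyphenyl is the group found in the compound with the lowest number. A higher number is therefore expected for compound 4, by a 100-fold higher number from compound 1 to compound 4 (2.00 log units; beyond the scatter). The estimate for compound 4 is 100 nM, with a range from 10 nM to 1000 nM.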

Compound 4, effective concentration (reported as EC, without a stated level of effect): 10 nM
Compound 4: the middle estimate sits 10-fold (1.00 log units) above what was measured; low and high end bracket the measured number.
By their numbers in this assay, from the lowest: compound 1; then compound 4; then compound 3; then compound 2.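

Within the data shown here, the step of a 10-fold higher number from compound 1 to compound 4 (1.00 log units; beyond the scatter) is the first one measured on the amide side with the unsubstituted phenyl of the sulfonamide kept in place, and it shows that the group on this carbonyl carbon matters there too, not only in the pair of compound 2 and compound 3. Among these compounds, it also shows that 2-methoxyphenyl is not the only group compatible with a number in this range: in this assay compound 4 , whose 2,4,6-trichlorophenyl has three chlorine atoms and no hydrogen-bond acceptor, gives 10 nM, although the change is still beyond the scatter and 2-methoxyphenyl keeps the lower number in this pair. Nothing available here explains why this exchange raises the number.

Going by these compounds, it remains open whether all three chlorine atoms are needed, since a phenyl carrying a single chlorine, or a longer chain such as n-butyl on the carbonyl carbon, would separate the aryl ring from its substituents. On these data alone, it is also open whether the same exchange would give a step of similar size in a compound with a methyl group on the sulfonamide side.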